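Cytotoxicity limits in a small amide series

The source may hold more compounds than are shown below. What is called first, only, known or untested is meant among the compounds shown, and "the series" means these compounds.

Measured compounds:
compound 1 `CC(C)=CC(=O)Nc1cccc(Oc2nc(Nc3ccn(C)n3)nc3c2CSCC3)c1`: > 50000 nM
compound 2 `CC(C)/C=C/C(=O)Nc1cccc(Oc2nc(Nc3ccn(C)n3)nc3c2CSCC3)c1`: > 50000 nM
compound 3 `COc1ccc(Nc2nc3c(c(Oc4cccc(NC(=O)C=C(C)C)c4)n2)CSCC3)cc1`: > 50000 nM

In an ADME assay on L02 cells (Homo sapiens) for cytotoxicity, read by MTT assay, with a stated time of 72 h (on this read-out higher numbers stand for weaker inhibition and lower numbers for stronger inhibition), compound 1 gives > 50000 nM, which is a limit of the assay and not a number. Compound 2 gives > 50000 nM, again a limit. Compound 3 gives > 50000 nM, also a limit. All three values therefore sit at the limit of > 50000 nM in this assay, at which 3 of the 3 values shown sit, and no ordering among them can be read.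

Compound 1 and compound 2 differ by 3-methylbut-1-en-1-yl in place of 2-methylprop-1-en-1-yl on a carbonyl carbon. The step that the two limits leave unreadable from compound 1 to compound 2 is unreadable, since both ends are limits. The two cores differ by 4-methoxyphenyl in place of 1-methyl-1H-pyrazol-3-yl on a nitrogen on an aromatic ring, and the step that the two limits leave unreadable from compound 1 to compound 3 is likewise unreadable.

Compound 4 `COc1ccc(Nc2nc3c(c(Oc4cccc(NC(=O)/C=C/C(C)C)c4)n2)CSCC3)cc1` is not yet measured. It differs from compound 3 by 3-methylbut-1-en-1-yl in place of 2-methylprop-1-en-1-yl on a carbonyl carbon, the same change as that from compound 1 to compound 2, made at the same kind of place. The expected step that the limit leaves unreadable from compound 3 to compound 4 rests on compound 1 and compound 2 both sitting at the limit of > 50000 nM in this assay, at which 3 of the 3 values shown sit, so the change is expected to leave the read-out at the limit again. For compound 4 the estimate in this assay is 60000 nM, within 30000 nM to 150000 nM, with a limit rather than a number the most likely outcome.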

Compound 4, half-maximal inhibitory concentration: > 50000 nM
Compound 4 was reported as a limit; the forecaster's own chance of this, stated with the estimate: 85%; the middle value is on the limit's open side.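

In this assay compound 4 gives > 50000 nM, a limit and not a number. No new step can be read, neither from compound 3 to compound 4 nor from compound 2 to compound 4, since all the values share one limit: the limit of > 50000 nM in this assay, at which 4 of the 4 values shown sit. The compounds shown leave open how far each lies beyond that limit, and whether either change alters cytotoxicity at all.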